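The source may hold more compounds than are shown below. What is called first, only, known or untested is meant among the compounds shown, and "the series" means these compounds.

Compound 3 `CCOc1cccc(N2CCN(C(=O)c3oc(C)nc3-c3ccccc3)CC2)c1` carries a 3-ethoxyphenyl on an amine nitrogen in a ring; in a functional assay on HL-60 cells (Homo sapiens) for inhibition, read by MTT assay, with a stated time of 72 h (on this read-out higher numbers stand for weaker inhibition and lower numbers for stronger inhibition), compound 3 gives 151 nM, the highest of the three numbers seen. Compound 1 `Cc1nc(-c2ccccc2)c(C(=O)N2CCN(c3c(C)cccc3C)CC2)o1` gives 146 nM, and the step of a 1.0-fold higher number from compound 1 to compound 3 (0.01 log units; within the scatter) stays within the scatter. Compound 2 `COc1cc(OC)cc(N2CCN(C(=O)c3oc(C)nc3-c3ccccc3)CC2)c1` gives 19.2 nM; the steps of a 7.6-fold lower number from compound 1 to compound 2 (0.88 log units; beyond the scatter) and a 7.9-fold higher number from compound 2 to compound 3 (0.90 log units; beyond the scatter) are the only ones beyond the scatter, and both involve the 3,5-dimethoxyphenyl of compound 2. Compound 4 `Cc1nc(-c2ccccc2)c(C(=O)N2CCN(c3cccc(Cl)c3)CC2)o1` differs from compound 3 by chloro in place of ethoxy on an aromatic carbon. Going by the values given here, no measured step replaces ethoxy with chloro, and compound 1 and compound 3 sit together despite differing on the same ring, so the expected step of a 1.0-fold lower number from compound 3 to compound 4 (0.00 log units; within the scatter) is none beyond the scatter. Compound 4 is estimated at 150 nM, within 50 nM to 450 nM.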

Compound 4, half-maximal inhibitory concentration: 39.2 nM
Compound 4: the middle estimate sits 3.8-fold (0.58 log units) above what was measured, and the stated range ends above it.
By their numbers in this assay, from the lowest: compound 2; then compound 4; then compounds 1 and 3 (each within the scatter of the next).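

Chloro in place of ethoxy on the aromatic carbon gives a 3.9-fold lower number from compound 3 to compound 4 (0.59 log units; beyond the scatter) in this assay and so shows that this place on the ring responds to its substituent, which the near match of compound 1 and compound 3 had not suggested. The 3-chlorophenyl also compares with the other two aryl groups through a 3.7-fold lower number from compound 1 to compound 4 (0.57 log units; beyond the scatter) and a 2.0-fold higher number from compound 2 to compound 4 (0.31 log units; beyond the scatter), leaving compound 2 with the lowest number. Nothing measured here explains the chloro result.

On these data alone, whether chloro itself matters or ethoxy merely costs activity remains open. Fluoro, methoxy, an amine or a bare hydrogen at this place could separate those readings.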